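Acetyl for Cyano: Expected Clearance in Mouse Liver Microsomes

A few compounds are considered here, and "the series" means these few. Any claim that something is new, unique, unknown or untested is made for them only; others in the source may bear on it.

Of the compounds shown here, two sharing one core have been measured in an ADME assay on microsomes from liver (Mus musculus) for metabolic stability, using NADPH, with a stated time of 60 min; on this read-out higher numbers stand for fast clearance and lower numbers for slow clearance. Compound 1, `O=C(Nc1cccc(C(=O)O)c1)Nc1ccc(F)c(C(F)(F)F)c1`, reaches only a limit of the assay, < 7 uL/min. Among the measured compounds shown here, compound 2, `N#Cc1ccc(NC(=O)Nc2ccc(F)c(C(F)(F)F)c2)cc1`, gives 12 uL/min in this assay and is the only compound with a numerical value in the set. The other entry is the limit of < 7 uL/min in this assay, at which 1 of the 2 values shown sits. Compound 3, `CC(=O)c1ccc(NC(=O)Nc2ccc(F)c(C(F)(F)F)c2)cc1`, has not yet been measured; it carries acetyl in place of cyano on an aromatic carbon, a change counted as acetyl in place of cyano on an aromatic carbon. For the measured compounds named here, no measured pair of compounds differs in a single place, so no step between measured compounds is known. Resting on compound 2 alone, compound 3 is expected to shift by a 1.3-fold higher number from compound 2 to compound 3 (0.10 log units; within the scatter), a step that need not exceed the usual scatter of this assay. Compound 3 is therefore estimated at 15 uL/min in this assay, with a range from 7 uL/min to 35 uL/min.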

Compound 3, intrinsic clearance in a liver preparation (reported as CLH), per the amount of preparation that the assay uses: 14 uL/min
The estimate for compound 3 lay 1.1-fold (0.03 log units) above the measured number; low and high end bracket the measured number.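

In this assay, acetyl in place of cyano on an aromatic carbon, para to a large group, gives a 1.2-fold higher number from compound 2 to compound 3 (0.07 log units; within the scatter), so this read-out does not tell the two groups apart. This is the only step shown that changes a single place on the shared core, and it shows that this position takes acetyl, with its 3 heavy atoms, in place of cyano, with its 2, without a step beyond the scatter. Nothing measured here explains why the two groups read alike.

As far as these compounds go, whether an amine, a methoxy group or a longer chain at this carbon would read the same stays open. Among the compounds shown here, compound 1 gives < 7 uL/min, which is a limit of the assay and not a number, and it differs from compound 2 in more than one place, so no step to it can be read.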